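The source may hold more compounds than are shown below. What is called first, only, known or untested is meant among the compounds shown, and "the series" means these compounds.

Compound 1 `O=C(O)COc1ccc(Cl)cc1C#Cc1cccc(C(F)(F)F)c1` gives 92 nM in an assay on CHO cells for displacement of a labelled ligand from prostaglandin D2 receptor 2 (Homo sapiens), read by scintillation counting; a lower number here means a stronger inhibitor, a higher number a weaker inhibitor. Compound 2 `CS(=O)(=O)c1cccc(C#Cc2cc(Cl)ccc2OCC(=O)O)c1` gives 15 nM and is the lower of the two numbers; the one measured step, a 6.1-fold lower number from compound 1 to compound 2 (0.79 log units; beyond the scatter), covers methylsulfonyl in place of trifluoromethyl and is the only step shown. Compound 3 `CN(C)S(=O)(=O)c1cccc(C#Cc2cc(Cl)ccc2OCC(=O)O)c1` differs from compound 2 by dimethylamino in place of methyl on a sulfonyl sulfur. Among the compounds with values here, no measured step touches the substituent on the sulfonyl sulfur, so the measured step gives no direct guide, and the step of a 1.3-fold higher number from compound 2 to compound 3 (0.12 log units; within the scatter) from compound 2 to compound 3 is expected to stay within the scatter. Compound 3 is estimated at 20 nM, in the range 7 nM to 60 nM.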

Compound 3, inhibition constant: 14 nM
For compound 3 the middle estimate is 1.4-fold (0.15 log units) above the measured one; the measured number falls inside the stated range.
By their numbers in this assay, from the lowest: compounds 3 and 2 (each within the scatter of the next); then compound 1.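

The substituent on the sulfonyl sulfur now has a measured step: dimethylamino in place of methyl gives a 1.1-fold lower number from compound 2 to compound 3 (0.03 log units; within the scatter), so three heavy atoms and one at this place read alike. Dimethylsulfamoyl in place of trifluoromethyl on the aromatic carbon gives a 6.6-fold lower number from compound 1 to compound 3 (0.82 log units; beyond the scatter), a step of the same order as the one for methylsulfonyl. No supporting data explain either step. Open, as far as these compounds go, is whether a piperidine ring or a plain amino group on the sulfonyl sulfur would also read alike. Also open, from the compounds shown here alone, is whether a carboxamide could stand in place of the sulfonyl group.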